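Halogen swap on the fused ring of compound 3

This account rests on a few compounds, and the source may have more. Where it says the series, first, only, none or still open, it means among the compounds named here.

Measured compounds:
compound 1 `O=Cc1cn(-c2ccccc2)nc1-c1ccc(Cl)cc1` gives 15500 nM in a functional assay on HeLa cells (Homo sapiens) for antiproliferative activity, read by MTT assay, with a stated time of 48 h; on this read-out higher numbers stand for weaker inhibition and lower numbers for stronger inhibition
compound 2 `c1ccc(-c2nn(-c3ccccc3)cc2-c2nc3ccccc3[nH]2)cc1` gives 1550 nM in this assay
compound 3 `Fc1ccc2[nH]c(-c3cn(-c4ccccc4)nc3-c3ccccc3)nc2c1` gives 3610 nM in this assay

Compound 3 holds the second highest of the three numbers in this assay. Its nearest neighbour is compound 2, which gives 1550 nM; compound 1, with 15500 nM, lies furthest from it.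

The next compound, compound 4 `Brc1ccc2[nH]c(-c3cn(-c4ccccc4)nc3-c3ccccc3)nc2c1`, differs from compound 3 in one place: bromo in place of fluoro on an aromatic carbon.

Going by the values given here, only one measured step touches this part of the shared core, the introduction of fluoro on the same aromatic carbon, a 2.3-fold higher number from compound 2 to compound 3 (0.37 log units; beyond the scatter). Among the compounds with values here, no measured pair shows bromo in place of fluoro, or bromo in place of hydrogen, so the size of a halogen-to-halogen exchange at this carbon is unknown here. Given that the fluoro step from compound 2 to compound 3 was modest, a swap between two halogens is expected to move the number in this assay by no more than the scatter, in either direction, with a slight lean toward a higher number.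

Compound 4 is therefore estimated at 4000 nM, within 1500 nM to 11000 nM, which is expected to correspond to a 1.1-fold higher number from compound 3 to compound 4 (0.04 log units; within the scatter).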

Compound 4, half-maximal inhibitory concentration: 1760 nM
The estimate for compound 4 lay 2.3-fold (0.36 log units) above the measured number, within the range that was stated.
By their numbers in this assay, from the lowest: compounds 2 and 4 (each within the scatter of the next); then compound 3; then compound 1.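

Fluoro and bromo are not interchangeable on this aromatic carbon: in this assay the exchange gives a 2.1-fold lower number from compound 3 to compound 4 (0.31 log units; beyond the scatter), a modest step that only just clears the scatter. The earlier compounds shown here showed only that fluoro separates from hydrogen at this carbon, and the new comparison shows that bromo does not, with a 1.1-fold higher number from compound 2 to compound 4 (0.06 log units; within the scatter); of the three substituents now compared here, fluoro alone stands apart, while hydrogen and bromo cannot be told apart on this read-out. Nothing available bears on why the two halogens differ at this carbon.

As far as these compounds go, these notes rest on a single substituent carbon, one cell line and one read-out, so it remains open whether the same order of fluoro against bromo would hold on another carbon of the fused ring or with a different group on the rest of the shared core. From the compounds shown here alone, it also remains open whether a methoxy group, an amine or a carboxylic acid on this carbon would stay level with hydrogen and bromo or depart from them, as fluoro does, in either direction.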